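Urea aryl change from ethynylphenyl to bromo-methanesulfonamido-phenyl

The compounds below may be only part of what the source reports. "The series", "measured", "known", "first", "only" and "open" are said of these compounds alone.

Compound 1, `Cc1ccc(NC(=O)Nc2cccc(-c3nc(-c4ccc(NC(=O)c5cccnc5)cc4Cl)no3)c2)cc1`, in a functional assay on MDA-MB-231 cells (Homo sapiens) for antiproliferative activity, read by MTT assay, with a stated time of 72 h (on this read-out lower numbers stand for stronger inhibition and higher numbers for weaker inhibition), gives 3500 nM.
Compound 2, `O=C(Nc1cccc(-c2nc(-c3ccc(NC(=O)c4cccnc4)cc3Cl)no2)c1)Nc1cccc(C(F)(F)F)c1`, in this assay gives 1900 nM.
Compound 3, `C#Cc1cccc(NC(=O)Nc2cccc(-c3nc(-c4ccc(NC(=O)c5cccnc5)cc4Cl)no3)c2)c1`, in this assay gives only a limit, > 10000 nM.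

Compound 3 thus stands at the weak end of the three measured compounds, with no number but a limit (the limit of > 10000 nM in this assay, at which 1 of the 3 values shown sits). The steps that lead to it were both beyond the scatter: an at least 2.8-fold higher number from compound 1 to compound 3 (0.45 log units; beyond the scatter), and an at least 5.2-fold higher number from compound 2 to compound 3 (0.72 log units; beyond the scatter). Between compound 1 and compound 2 the change was a 1.8-fold lower number from compound 1 to compound 2 (0.27 log units; within the scatter).

Compound 4, `CS(=O)(=O)Nc1ccc(NC(=O)Nc2cccc(-c3nc(-c4ccc(NC(=O)c5cccnc5)cc4Cl)no3)c2)cc1Br`, differs from compound 3 in one place: 3-bromo-4-(methanesulfonamido)phenyl in place of 3-ethynylphenyl on an amide-type nitrogen. The measured steps show that the aryl group on this urea nitrogen can move the read-out in this assay by at least a modest amount, and that the 3-ethynylphenyl of compound 3 is the weakest of the three aryl groups seen. Since compound 4 carries a different aryl group again, a return towards the numbers of compound 1 and compound 2 is expected, estimated as an at least 2.0-fold lower number from compound 3 to compound 4 (0.30 log units; that floor lies within the scatter), though whether the new group reaches a measurable value is uncertain. For compound 4 in this assay the expected value is 5000 nM, between 1500 nM and 20000 nM.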

Compound 4, half-maximal inhibitory concentration: 700 nM
Compound 4: middle estimate off by 7.1-fold (0.85 log units), on the high side, and the stated range ends above it.
By their numbers in this assay, from the lowest: compound 4; then compounds 2 and 1 (each within the scatter of the next). At a limit, above all of these: compound 3.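

The 3-bromo-4-(methanesulfonamido)phenyl group on this amide-type nitrogen does more than bring the read-out in this assay back to the level of the simpler aryl groups, with a 2.7-fold lower number from compound 2 to compound 4 (0.43 log units; beyond the scatter) and a 5.0-fold lower number from compound 1 to compound 4 (0.70 log units; beyond the scatter). The urea aryl group can therefore take a substituted ring of 12 heavy atoms, with 1 hydrogen-bond donor and 2 hydrogen-bond acceptors, and compound 4 still has a lower number than compound 1 and compound 2, a step beyond the scatter in each case. The change from the 3-ethynylphenyl group, an at least 14-fold lower number from compound 3 to compound 4 (1.15 log units; beyond the scatter), can be read only as a floor, because compound 3 is held at a limit: the limit of > 10000 nM in this assay, at which 1 of the 4 values shown sits.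

The bromine and the methanesulfonamido group enter together, so the compounds shown cannot say how much of the drop in the number belongs to either one alone. As far as these compounds go, it remains open whether a phenyl carrying the methanesulfonamido group without the bromine, or one carrying a carboxylic acid or an amine in its place, would keep this read-out.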